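Sulfonamide series: moving from compound 3 to compound 4

This account rests on a few compounds, and the source may have more. Where it says the series, first, only, none or still open, it means among the compounds named here.

Compound 3 `COc1cccc(NS(=O)(=O)c2ccc(N3CCNC3=O)cc2)c1` has the lowest number of the three measured compounds in a functional assay on MCF7 cells (Homo sapiens) for antiproliferative activity, read by sulforhodamine B assay, with a stated time of 48 h (on this read-out higher numbers stand for weaker inhibition and lower numbers for stronger inhibition), giving 120 nM; compound 2 `O=C1NCCN1c1ccc(S(=O)(=O)Nc2ccc(Br)cc2)cc1` gives 240 nM and compound 1 `CCc1ccc(NS(=O)(=O)c2ccc(N3CCNC3=O)cc2)cc1` gives 810 nM. Compound 4 `Cc1ccc(NS(=O)(=O)c2ccc(N3CCNC3=O)cc2)cc1C` differs from compound 3 in one place: 3,4-dimethylphenyl in place of 3-methoxyphenyl on a sulfonamide nitrogen. Going by the values given here, no measured step swaps these two groups directly. The nearest guidance comes from the steps of a 6.8-fold lower number from compound 1 to compound 3 (0.83 log units; beyond the scatter) and a 2.0-fold lower number from compound 2 to compound 3 (0.30 log units; within the scatter), both of which end at the 3-methoxyphenyl of compound 3. Since compound 1 carries an alkyl-substituted phenyl and gives the highest number, compound 4 is expected to move back toward it, a rise of about a 3.3-fold higher number from compound 3 to compound 4 (0.52 log units; beyond the scatter). Compound 4 is therefore estimated at 400 nM, within 150 nM to 1200 nM.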

Compound 4, half-maximal inhibitory concentration: 230 nM
For compound 4 the middle estimate is 1.7-fold (0.24 log units) above the measured one; low and high end bracket the measured number.
By their numbers in this assay, from the lowest: compounds 3, 4 and 2 (each within the scatter of the next); then compound 1.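

In this assay the 3,4-dimethylphenyl on the sulfonamide nitrogen stands level with the 3-methoxyphenyl, with a 1.9-fold higher number from compound 3 to compound 4 (0.28 log units; within the scatter), and with the 4-bromophenyl, with a 1.0-fold lower number from compound 2 to compound 4 (0.02 log units; within the scatter). An alkyl-substituted phenyl at this position therefore need not give a number as high as that of compound 1, as a 3.5-fold lower number from compound 1 to compound 4 (0.55 log units; beyond the scatter) shows, and the methoxy oxygen is not required to reach this range. No supporting evidence accounts for these results. Going by these compounds, whether a phenyl bearing an amine, a carboxylic acid or a longer alkyl chain would stay in this range remains open.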